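The source may hold more compounds than are shown below. What is called first, only, known or untested is meant among the compounds shown, and "the series" means these compounds.

Measured in an ADME assay on L02 cells (Homo sapiens) for cytotoxicity, read by MTT assay, with a stated time of 24 h; on this read-out higher numbers stand for weaker inhibition and lower numbers for stronger inhibition:
- compound 1 `COc1cc(/C=C2\CN(C)C/C(=C\c3ccc(Cl)c(Cl)c3)C2=O)cc(OC)c1`: 10600 nM
- compound 2 `CN1C/C(=C\c2ccc(F)cc2)C(=O)/C(=C/c2cccc([N+](=O)[O-])c2)C1`: 17600 nM
- compound 3 `CN1C/C(=C\c2ccc(Cl)cc2)C(=O)/C(=C/c2cccc([N+](=O)[O-])c2)C1`: > 20000 nM (a limit)

Compound 3 has no number in this assay, and its > 20000 nM is a limit of the assay.

The next analogue is compound 4 `CN1C/C(=C\c2cccc([N+](=O)[O-])c2)C(=O)/C(=C/c2ccc(Cl)c(Cl)c2)C1`. The change is chloro in place of hydrogen on an aromatic carbon, taking 4-chlorophenyl to 3,4-dichlorophenyl: chloro in place of hydrogen on an aromatic carbon.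

For the measured compounds named here, only one measured step lies close to this change, and it is a different substitution: an at least 1.1-fold higher number from compound 2 to compound 3 (0.05 log units; that floor lies within the scatter), chloro in place of fluoro on an aromatic carbon. Its floor lies within the scatter, so it gives little guidance on size. The 3,4-dichlorophenyl group also occurs in compound 1, which gives 10600 nM, but its other aryl group differs from that of compound 4.

A modest move toward lower numbers in this assay is therefore expected, though a result at the limit remains possible. The expected value for compound 4 is 14000 nM, with an estimated range of 7000 nM to 28000 nM. This estimate corresponds to an at least 1.4-fold lower number from compound 3 to compound 4 (0.15 log units; that floor lies within the scatter).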

Compound 4, half-maximal inhibitory concentration: 14800 nM
For compound 4 the middle estimate is 1.1-fold (0.02 log units) below the measured one; the measured number falls inside the stated range.
By their numbers in this assay, from the lowest: compounds 1, 4 and 2 (each within the scatter of the next). At a limit, above all of these: compound 3.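

In this assay, chloro in place of hydrogen on this aromatic carbon, ortho to a chloro group, gives an at least 1.3-fold lower number from compound 3 to compound 4 (0.13 log units; that floor lies within the scatter). The true size of this step stays unresolved because compound 3 stands at a limit, which allows only a floor: the limit of > 20000 nM in this assay, at which 1 of the 4 values shown sits. The 3,4-dichlorophenyl and 4-fluorophenyl groups are not told apart on this read-out, with 3,4-dichlorophenyl in place of 4-fluorophenyl giving a 1.2-fold lower number from compound 2 to compound 4 (0.08 log units; within the scatter).

The compounds shown leave open whether this position responds to anything other than halogen. A hydroxyl group or an amine at the same aromatic carbon could show whether this assay moves beyond the scatter with such a change.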